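Moving the Bromine: From Compound 3 to Compound 4

The source may hold more compounds than are shown below. What is called first, only, known or untested is meant among the compounds shown, and "the series" means these compounds.

Measured in a functional assay on SW480 cells (Homo sapiens) for cytotoxicity, read by MTT assay, with a stated time of 48 h; on this read-out lower numbers stand for stronger inhibition and higher numbers for weaker inhibition:
- Compound 1 `O=c1ccoc2cc(OCc3cn(Cc4ccc(Cl)cc4)nn3)ccc12`: > 100000 nM (a limit, not a number)
- Compound 2 `O=c1ccoc2cc(OCc3cn(Cc4ccc(Cl)cc4Cl)nn3)ccc12`: > 100000 nM (a limit, not a number)
- Compound 3 `O=c1ccoc2cc(OCc3cn(Cc4ccc(Br)cc4)nn3)ccc12`: 37500 nM

Among the compounds with values here, compound 3, at 37500 nM, gives the only true number here. The other two values sit at the limit of > 100000 nM in this assay, at which 2 of the 3 values shown sit.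

Compound 4 `O=c1ccoc2cc(OCc3cn(Cc4ccccc4Br)nn3)ccc12` keeps the same atoms but has 2-bromophenyl in place of 4-bromophenyl on a saturated chain carbon bound to an aromatic nitrogen.

Within the data shown here, two measured steps bear on this change: an at least 2.6-fold lower number from compound 1 to compound 3 (0.42 log units; beyond the scatter), and an at least 2.6-fold lower number from compound 2 to compound 3 (0.42 log units; beyond the scatter). Neither moves the bromo group, so they offer only indirect guidance. Compound 2, whose 2,4-dichlorophenyl is the closest match to 2-bromophenyl, stays at the limit of > 100000 nM. That points toward weaker inhibition, so a modest rise is expected in this assay, and a reading at the limit is also possible. The expected step is a 1.6-fold higher number from compound 3 to compound 4 (0.20 log units; within the scatter). For compound 4 the estimate is 60000 nM, with an expected range of 25000 nM to 100000 nM.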

Compound 4, half-maximal inhibitory concentration: > 100000 nM
Compound 4: only a limit was reported (the forecaster's own chance of this, stated with the estimate: 40%); middle value at least 1.6-fold (0.22 log units) from the limit.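

In this assay, the shift from 4-bromobenzyl to 2-bromobenzyl gives an at least 2.6-fold higher number from compound 3 to compound 4 (0.42 log units; beyond the scatter), so where the bromo group sits matters even with the same atoms. Within the data shown here, the earlier steps changed which halogen was present or how many there were, so this is the first pair in which only the place of the bromo group differs. Compound 4 gives > 100000 nM, which is a limit and not a number, and most of the series now reads this way: the limit of > 100000 nM in this assay, at which 3 of the 4 values shown sit.

Going by these compounds, the steps joining compound 4 to compound 1 or compound 2 cannot be read, and how far compound 4 lies past its limit stays unknown. Also open, on these data alone, is whether the activity of compound 3 would survive a methoxy group or an amine in place of the bromo group.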